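This account rests on a few compounds, and the source may have more. Where it says the series, first, only, none or still open, it means among the compounds named here.

Measured so far in an assay on CHO cells for displacement of a labelled ligand from adenosine receptor A3 (Homo sapiens), read by scintillation counting, with a stated time of 3 h; a higher number here means a weaker inhibitor, a lower number a stronger inhibitor:
Compound 1, `Cc1ccccc1-c1nc2c(NC3CCCC3)ncnc2n1C`: 3000 nM
Compound 2, `Cn1c(-c2ccccc2)nc2c(NC3CCC3)ncnc21`: 280 nM

Compound 2 stands at the lowest of the two numbers. Going by the values given here, compound 1 gives the higher number, and the gap between compound 1 and compound 2 lies beyond the usual scatter; the two differ in more than one place, so no single step between them is known.

Compound 3, `Cn1c(-c2ccccc2)nc2c(NC3CCCC3)ncnc21`, is not yet measured in this assay. It differs from compound 2 in one place: cyclopentyl in place of cyclobutyl on a nitrogen on an aromatic ring. Among the compounds with values here, no measured pair isolates this change. Compound 1 also carries a cyclopentyl on that nitrogen, but with a further difference, so its value cannot be read as the effect of the ring size alone.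

For compound 3 a small step toward a higher number is expected, a 2.1-fold higher number from compound 2 to compound 3 (0.33 log units; beyond the scatter), possibly within the scatter. Compound 3 is therefore estimated at 600 nM, with a range from 150 nM to 2500 nM.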

Compound 3, inhibition constant: 846 nM
The estimate for compound 3 lay 1.4-fold (0.15 log units) below the measured number; low and high end bracket the measured number.
By their numbers in this assay, from the lowest: compound 2; then compound 3; then compound 1.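

In this assay, going by these compounds alone, cyclopentyl in place of cyclobutyl on a nitrogen on an aromatic ring gives a step beyond the scatter (a 3.0-fold higher number from compound 2 to compound 3 (0.48 log units; beyond the scatter)), so this position distinguishes the two ring sizes, which no earlier pair could show. Compound 3 also isolates the methyl on an aromatic carbon: hydrogen in its place gives a step beyond the scatter as well (a 3.5-fold lower number from compound 1 to compound 3 (0.55 log units; beyond the scatter)), so the gap between compound 1 and compound 2 now divides into two single changes, each lowering the number along the way from compound 1 through compound 3 to compound 2. Nothing available explains either step.

The compounds shown leave open how cyclopropyl, cyclohexyl or an open chain such as isopropyl would behave on that nitrogen. They also leave open whether a methoxy or a chlorine in place of the methyl would give a similar step, and whether the methyl step holds with cyclobutyl on the nitrogen.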